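The source may hold more compounds than are shown below. What is called first, only, known or untested is meant among the compounds shown, and "the series" means these compounds.

Of the compounds shown here, three built on one shared core have so far been tested in a functional assay on PC-3 cells (Homo sapiens) for inhibition; on this read-out lower numbers stand for stronger inhibition and higher numbers for weaker inhibition. Compound 1 `COc1cc2nc(N3CCN(C(=O)c4cccc5ccccc45)CC3)nc(N)c2cc1OC` gives 59000 nM. Compound 2 `COc1cc2nc(N3CCN(S(=O)(=O)c4ccccc4[N+](=O)[O-])CC3)nc(N)c2cc1OC` gives 35000 nM, and compound 3 `COc1cc2nc(N3CCN(S(=O)(=O)c4cccc([N+](=O)[O-])c4)CC3)nc(N)c2cc1OC` gives 32000 nM, the lowest number of the three, although its gaps to compound 2 and to compound 1 both fall within the scatter. Compound 4 `COc1cc2nc(N3CCN(S(=O)(=O)c4ccc(S(C)(=O)=O)cc4)CC3)nc(N)c2cc1OC` differs from compound 3 by 4-(methylsulfonyl)phenyl in place of 3-nitrophenyl on a sulfonyl sulfur. Within the data shown here, the only measured step on the sulfonyl sulfur, a 1.1-fold lower number from compound 2 to compound 3 (0.04 log units; within the scatter), exchanged one nitrophenyl for another and stayed within the scatter; no measured step exchanges the nitro group for a different group. The expected step is therefore no change at the digits printed from compound 3 to compound 4 (within the scatter), that is, none beyond the scatter. Compound 4 is estimated at 32000 nM, with a range from 12000 nM to 85000 nM.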

Compound 4, half-maximal inhibitory concentration: 17000 nM
Compound 4: the middle estimate sits 1.9-fold (0.27 log units) above what was measured; low and high end bracket the measured number.
By their numbers in this assay, from the lowest: compounds 4, 3, 2 and 1 (each within the scatter of the next, the first and the last beyond it).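

Replacing a nitrophenyl on the sulfonyl sulfur with 4-(methylsulfonyl)phenyl gives a 1.9-fold lower number from compound 3 to compound 4 (0.27 log units; within the scatter) and a 2.1-fold lower number from compound 2 to compound 4 (0.31 log units; beyond the scatter) as the two steps, so only the second clears the scatter, and only modestly. Compound 4 thus shows that inhibition at this level does not depend on a nitro group at this position. Nothing measured here explains the steps. Still open, as far as these compounds go, is how an amine, a carboxylic acid or an unsubstituted phenyl on the sulfonyl sulfur would compare, and whether any group here can bring the numbers much lower.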